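The compounds below may be only part of what the source reports. "The series", "measured", "known", "first", "only" and "open" are said of these compounds alone.

Measured so far:
compound 1 `Oc1cccc(-c2cc(-c3ccc(F)cc3)cc(-c3cccc(O)c3)n2)c1` — 1280 nM
compound 2 `Oc1ccc(-c2cc(-c3ccccc3F)cc(-c3cccc(O)c3)n2)cc1` — 14300 nM
compound 3 `Oc1ccc(-c2cc(-c3cccc(F)c3)cc(-c3cccc(O)c3)n2)cc1` — 14200 nM

In a functional assay on HeLa cells (Homo sapiens) for inhibition (a higher number here means a weaker inhibitor, a lower number a stronger inhibitor), compound 3 stands second highest of the three numbers. Its nearest neighbour is compound 2, with a 1.0-fold lower number from compound 2 to compound 3 (0.00 log units; within the scatter) lying within the scatter. The furthest is compound 1, which shows a lower number, but compound 1 differs from compound 3 in two places at once, one hydroxyphenyl group and the fluorophenyl group, so its value alone cannot be assigned to either change.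

Compound 4 `Oc1ccc(-c2cc(-c3ccc(F)cc3)cc(-c3cccc(O)c3)n2)cc1` is not yet measured in this assay. It differs from compound 3 only in the fluorophenyl group: 4-fluorophenyl in place of 3-fluorophenyl on an aromatic carbon.

Among the compounds with values here, the only single-place step that bears on this, a 1.0-fold lower number from compound 2 to compound 3 (0.00 log units; within the scatter), moved the fluorine from one position of the phenyl ring to another and left the number unchanged within the scatter. Moving the fluorine once more within the same ring, on the shared core, is therefore expected to give a step of no more than the scatter, in either direction, and the estimate for compound 4 is set close to compound 3 with the move a 1.3-fold lower number from compound 3 to compound 4 (0.11 log units; within the scatter). Compound 4 is estimated at 11000 nM, with a range from 3500 nM to 35000 nM in this assay.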

Compound 4, half-maximal inhibitory concentration: 8080 nM
Estimate against measurement, compound 4: 1.4-fold (0.13 log units) above; measured number inside the range.
By their numbers in this assay, from the lowest: compound 1; then compounds 4, 3 and 2 (each within the scatter of the next).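

In this assay the fluorine has now been placed at all three positions of the phenyl ring on the shared core, and the reading is flat: a 1.8-fold lower number from compound 3 to compound 4 (0.24 log units; within the scatter) and a 1.8-fold lower number from compound 2 to compound 4 (0.25 log units; within the scatter) show that 4-fluorophenyl does not separate from 3-fluorophenyl or 2-fluorophenyl at this place, opposite the ring nitrogen. Compound 4 also turns the earlier two-place comparison with compound 1 into a single-place one, and a 6.3-fold higher number from compound 1 to compound 4 (0.80 log units; beyond the scatter) assigns a change beyond the scatter to 4-hydroxyphenyl in place of 3-hydroxyphenyl, the only step of this kind among the compounds shown. Nothing measured here bears on the reason for either result.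

Still open, on these data alone, is whether the hydroxyphenyl step holds with 2-fluorophenyl or 3-fluorophenyl on the core, and whether the fluorine position stays equally flat carrying two 3-hydroxyphenyl groups. Also open, as far as these compounds go, is how a methoxy group, an amine or a carboxylic acid would read in place of the hydroxyl on the hydroxyphenyl group, and how a chlorine or a nitrile would read in place of the fluorine.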